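A few compounds are considered here, and "the series" means these few. Any claim that something is new, unique, unknown or untested is made for them only; others in the source may bear on it.

Values measured in a functional assay on BHK-21 cells (Mesocricetus auratus) for antiproliferative activity, read by sulforhodamine B assay, with a stated time of 48 h, tested at 100 uM; a lower number here means less inhibition of growth, a higher number more inhibition of growth at the concentration tested:

- Compound 1 `Fc1ccc(-c2nn3c(-c4ccncc4)nnc3s2)cc1Cl`: 51.4%
- Compound 2 `Fc1ccc(OCc2nn3c(-c4ccncc4)nnc3s2)cc1`: 52.7%
- Compound 3 `Oc1ccc(OCc2nn3c(-c4ccncc4)nnc3s2)cc1`: 60.5%

On these numbers, compound 3 cannot be told apart from compound 1 or compound 2, as its gaps to both lie within the usual scatter of this assay. The next compound, compound 4 `COc1ccc(OCc2nn3c(-c4ccncc4)nnc3s2)cc1`, differs from compound 3 by methyl in place of hydrogen on an oxygen on an aromatic ring. This is methyl in place of hydrogen on an oxygen on an aromatic ring, so hydroxy becomes methoxy.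

Among the measured compounds shown here, only one measured step involves this group: a number 7.8 percentage points higher from compound 2 to compound 3 (within the scatter), with hydroxy in place of fluoro on an aromatic carbon. For the measured compounds named here, that step does not stand out from the scatter, and no measured step shows what adding the methyl does. No change beyond the scatter is therefore expected, and the estimated step is a number 5.5 percentage points lower from compound 3 to compound 4 (within the scatter). The expected value for compound 4 is 55%, with an estimated range of 42% to 68%.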

Compound 4, percent growth inhibition at one concentration: 74%
Compound 4: the middle estimate sits 19 percentage points below what was measured, and the stated range ends below it.
By their numbers in this assay, from the lowest: compounds 1, 2 and 3 (each within the scatter of the next); then compound 4.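

At this position on the ring, what sits on the oxygen makes a visible difference: in this assay, methyl in place of hydrogen gives a number 13.5 percentage points higher from compound 3 to compound 4 (beyond the scatter) and turns hydroxy into methoxy. Methoxy in place of fluoro gives a number 21.3 percentage points higher from compound 2 to compound 4 (beyond the scatter) as well, whereas hydroxy in place of fluoro gave only a number 7.8 percentage points higher from compound 2 to compound 3 (within the scatter), so of these three groups methoxy is the one that separates from the other two. Nothing available here accounts for why the added methyl has this effect.

Going by these compounds, whether a longer chain on that oxygen, such as ethyl, would carry this rise further remains open, as does what an amine in place of the methoxy would do. On these data alone, all of these readings come from a single concentration, so how the compounds would compare at other concentrations also stays unknown.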